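Swapping the sulfonamide substituent of compound 3

The source may report more compounds than this note shows. Statements on the series, on what has been measured and on what is new or still open speak of the compounds shown alone.

Three compounds built on one shared core differ only in the group attached to the sulfonamide nitrogen. Compound 1 `CC(C)NS(=O)(=O)c1ccc2c(c1)C(n1ccccc1=O)=CC(C)(C)O2` carries an isopropyl there and gives 676 nM in a functional assay with Rattus norvegicus as the target; a lower number here means that less compound is needed, a higher number that more compound is needed for the effect. Compound 2 `CC1(C)C=C(n2ccccc2=O)c2cc(S(=O)(=O)NCc3ccccc3)ccc2O1` carries a benzyl and gives 525 nM in this assay. Compound 3 `CC1(C)C=C(n2ccccc2=O)c2cc(S(=O)(=O)Nc3ccc(C#N)cc3)ccc2O1` carries a 4-cyanophenyl and gives 263 nM in this assay, the lowest of the three numbers. The step of a 2.6-fold lower number from compound 1 to compound 3 (0.41 log units; beyond the scatter) is modest but beyond the scatter, while the steps of a 1.3-fold lower number from compound 1 to compound 2 (0.11 log units; within the scatter) and a 2.0-fold lower number from compound 2 to compound 3 (0.30 log units; within the scatter) stay within it.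

Compound 4 `CN(c1ccccc1)S(=O)(=O)c1ccc2c(c1)C(n1ccccc1=O)=CC(C)(C)O2` is the next variation: methyl(phenyl)amino in place of (4-cyanophenyl)amino on a sulfonyl sulfur. Among the compounds with values here, the steps from compound 1 and compound 2 to compound 3 show that an aromatic ring on that nitrogen lowers the number somewhat; no measured step shows what removing the nitrile or adding a methyl on that nitrogen does. The aromatic ring remains, so compound 4 is expected to sit close to compound 3, with a step of a 1.5-fold higher number from compound 3 to compound 4 (0.18 log units; within the scatter) in this assay that is estimated to fall within the scatter. Compound 4 is therefore expected to give about 400 nM in this assay, within a range from 150 nM to 1200 nM.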

Compound 4, half-maximal effective concentration: 1.74 nM
Estimate against measurement, compound 4: 230-fold (2.36 log units) above; the measured number lies below the stated range.
By their numbers in this assay, from the lowest: compound 4; then compounds 3, 2 and 1 (each within the scatter of the next, the first and the last beyond it).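

Within the data shown here, the group on the sulfonyl sulfur can matter far more than the earlier steps, which were modest at most, suggested: in this assay, methyl(phenyl)amino gives a 150-fold lower number from compound 3 to compound 4 (2.18 log units; beyond the scatter), and likewise a 300-fold lower number from compound 2 to compound 4 (2.48 log units; beyond the scatter) and a 390-fold lower number from compound 1 to compound 4 (2.59 log units; beyond the scatter). Compared with (4-cyanophenyl)amino, the entering group has lost the nitrile and has a methyl on the nitrogen, leaving no hydrogen-bond donor, so two features change in a single step. Nothing measured here explains the size of this drop.

The compounds shown leave open which of the two features carries the step; phenylamino or methyl(4-cyanophenyl)amino on the sulfonyl sulfur would separate them. As far as these compounds go, whether ethyl(phenyl)amino, with a longer chain on that nitrogen, would keep the number this low also remains open.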